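A few compounds are considered here, and "the series" means these few. Any claim that something is new, unique, unknown or untested is made for them only; others in the source may bear on it.

Compounds measured in an ADME assay on the whole organism (strain Sprague-Dawley) for pharmacokinetics, with Rattus norvegicus as the target, at a dose of 5 mg/kg by the oral route; a higher number here means that a larger share of the oral dose reaches the circulation, a lower number that a smaller share of the oral dose reaches the circulation:

Compound 1: `CC(C)c1ccc2c(Nc3cc(C(=O)N[C@@H](C)c4ccccc4)ccc3Sc3ccc(N)cc3)ncnc2n1` gives 42.4%
Compound 2: `CC(C)c1ccc2c(Nc3cc(C(=O)N[C@@](C)(CO)c4ccccc4)ccc3Sc3ccc(N)cc3)ncnc2n1` gives 13.3%

Among the measured compounds shown here, of these two numbers, compound 1 stands highest; the only comparison is a number 29.1 percentage points lower from compound 1 to compound 2 (beyond the scatter), a drop that goes beyond the scatter of repeated measurements. That step, however, alters the saturated chain carbon next to the amide, not the aromatic amine.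

Compound 3, `COC(=O)Nc1ccc(Sc2ccc(C(=O)N[C@@H](C)c3ccccc3)cc2Nc2ncnc3nc(C(C)C)ccc23)cc1`, is built from compound 1 by a change at a different place: methoxycarbonyl in place of hydrogen on a nitrogen on an aromatic ring. For the measured compounds named here, no measured pair in this set shares that change, so the only step available, the one from compound 1 to compound 2, is of a different kind and does not bear directly on it. With nothing to go on but the unchanged remainder of the molecule, the expectation is a modest step, most likely downward but not reliably beyond the scatter, a number 10.4 percentage points lower from compound 1 to compound 3 (beyond the scatter). Compound 3 is therefore expected to reach about 32%, with a range from 12% to 55%.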

Compound 3, oral bioavailability: 0%
Beside the measured number, compound 3's estimate is 32 percentage points above it; measured number below the stated range.
By their numbers in this assay, from the lowest: compound 3; then compound 2; then compound 1.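

The nitrogen of the 4-aminophenyl group turns out to be a sensitive place: in this assay the change from amino to (methoxycarbonyl)amino gives a number 42.4 percentage points lower from compound 1 to compound 3 (beyond the scatter) and is larger than a number 29.1 percentage points lower from compound 1 to compound 2 (beyond the scatter) at the saturated chain carbon. So the earlier compounds, which all carry the free amino group, gave no sign that a change on this nitrogen could take compound 3 down to 0% in this assay. Nothing available explains this fall in the share of the dose reaching the circulation.

As far as these compounds go, it remains open whether a smaller group on the same nitrogen, such as acetyl or methyl, would give a similar drop or a milder one. Also open, from the compounds shown here alone, is how methoxycarbonyl on this nitrogen would read alongside the hydroxymethyl of compound 2.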